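The compounds below may be only part of what the source reports. "The series", "measured", "known", "first", "only" and "open" are said of these compounds alone.

Measured so far in a functional assay on CCRF-CEM cells (Homo sapiens); a higher number here means a weaker inhibitor, a lower number a stronger inhibitor:
- compound 1 `CC1=CC(=N)C(c2ccccc2)(c2ccccc2)O1`: 29.3 ug/mL
- compound 2 `C/C(=C\COc1ccc2ccc(=O)oc2c1)C1=CC(=N)C2(CCCCC2)O1`: 4.95 ug/mL
- compound 3 `O=C1C=C(c2ccccc2)OC1`: 30.2 ug/mL

Compound 3 gives the highest of these three numbers, yet compound 1 stands within the usual scatter of it, so the two cannot be told apart; only compound 2 stands clearly lower, beyond the scatter. Compound 4 `COc1ccccc1C1=CC(=O)CO1` differs from compound 3 in one place: methoxy in place of hydrogen on an aromatic carbon. For the measured compounds named here, no measured pair shows what this kind of change does in this assay, so there is nothing to lean on. A small group of this size is expected to move the number little, if at all, and the step from compound 3 to compound 4 is expected to be a 1.2-fold lower number from compound 3 to compound 4 (0.08 log units; within the scatter), no larger than the scatter. For compound 4 the expected value is 25 ug/mL, with a range from 10 ug/mL to 60 ug/mL.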

Compound 4, concentration for 50% inhibition: > 100 ug/mL
Compound 4: no number, only a limit (the forecaster's own chance of this, stated with the estimate: 10%); middle value at least 4.0-fold (0.60 log units) away from the limit.
By their numbers in this assay, from the lowest: compound 2; then compounds 1 and 3 (each within the scatter of the next). At a limit, above all of these: compound 4.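

In this assay, methoxy in place of hydrogen on this aromatic carbon, ortho to a group of 6 heavy atoms, gives an at least 3.3-fold higher number from compound 3 to compound 4 (0.51 log units; beyond the scatter). For the compounds shown here, this is the first sign that so small a change here can weaken inhibition beyond the scatter. Compound 4 gives > 100 ug/mL, which is a limit and not a number, so the full size of the step stays unknown: the limit of > 100 ug/mL in this assay, at which 1 of the 4 values shown sits.

Going by these compounds, whether an amine or a hydroxyl on the same carbon would act as methoxy does stays open. So does what methoxy would do elsewhere on this ring.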